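The compounds below may be only part of what the source reports. "The series", "measured", "known", "first", "only" and "open" are said of these compounds alone.

Measured in an in vitro assay on FRT cells for binding affinity to Cystic fibrosis transmembrane conductance regulator (Homo sapiens), read by fluorescence, with a stated time of 20 h; a higher number here means that more compound is needed for the effect, a lower number that less compound is needed:
compound 1 `CCOC(=O)c1cc(-c2sc(NC(=O)C(C)(C)C)nc2C)nn1Cc1ccccc1` gives 8500 nM
compound 2 `COc1ccc(NC(=O)c2cc(-c3sc(NC(=O)C(C)(C)C)nc3C)n(-c3ccc(Br)cc3)n2)cc1` gives 3400 nM
compound 3 `C=CCn1nc(C(=O)Nc2ccc(OC)cc2)cc1-c1sc(NC(=O)C(C)(C)C)nc1C` gives 930 nM

Compound 3 stands lowest of the three numbers in this assay; compound 2 is nearest to it and compound 1 furthest, both separated from it beyond the scatter. Among the compounds with values here, the only single-point step among the measured set, a 3.7-fold lower number from compound 2 to compound 3 (0.56 log units; beyond the scatter), concerns the aromatic nitrogen, not the amide. Compound 4 `C=CCn1nc(C(=O)NCc2ccccc2)cc1-c1sc(NC(=O)C(C)(C)C)nc1C` differs from compound 3 at the amide nitrogen instead: benzyl in place of 4-methoxyphenyl on an amide-type nitrogen. Within the data shown here, no measured pair isolates a change on the amide nitrogen, so the measured step bears on this change only indirectly and gives no direction for it. Among the measured compounds shown here, compound 1, which carries an ethyl ester and a benzyl group on the aromatic nitrogen, has the highest number, but its several differences from compound 3 allow no step to be read. In this assay the number for compound 4 is therefore expected to lie near that of compound 3, with wide uncertainty, at 1500 nM within 500 nM to 5000 nM. This estimate for compound 4 means a step of a 1.6-fold higher number from compound 3 to compound 4 (0.21 log units; within the scatter), expected to remain within the scatter.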

Compound 4, half-maximal effective concentration: 3000 nM
Compound 4: middle estimate off by 2.0-fold (0.30 log units), on the low side, and the stated range covers the measured number.
By their numbers in this assay, from the lowest: compound 3; then compounds 4 and 2 (each within the scatter of the next); then compound 1.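

In this assay the amide nitrogen turns out to be a position that responds to its substituent: benzyl in place of 4-methoxyphenyl gives a 3.2-fold higher number from compound 3 to compound 4 (0.51 log units; beyond the scatter), a modest step beyond the scatter. Within the data shown here, until now, the only readable step concerned the aromatic nitrogen, so this is the first single-point reading on the amide side. With the allyl group held constant, the 4-methoxyphenyl amide carries the lower number of the two. Nothing available here explains this step.

The change alters both the methoxy group and the way the ring is attached to the amide nitrogen, so the compounds shown do not separate the two; an unsubstituted phenyl or a 4-methoxybenzyl group there would. On these data alone, how a longer chain such as phenethyl would read at this nitrogen also stays open.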